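The compounds below may be only part of what the source reports. "The series", "measured", "known", "first", "only" and "open" are said of these compounds alone.

Working notes on the sulfonyl-quinoline series.

The measured set consists of compound 1 `O=S(=O)(c1ccc(F)cc1)c1cnc2ccc(Cl)cc2c1-c1ccc(Cl)cc1`, compound 2 `N#Cc1ccc2ncc(S(=O)(=O)c3ccc(F)cc3)c(-c3ccc(Cl)cc3)c2c1` and compound 3 `O=S(=O)(c1ccc(F)cc1)c1cnc2cc(Cl)ccc2c1-c1ccc(Cl)cc1`. In an assay on cell membranes for displacement of a labelled ligand from metabotropic glutamate receptor 5 (Rattus norvegicus), with a stated time of 60 min, tested at 1 uM (a higher number here means more inhibition at the concentration tested (going by the name of the read-out), a lower number less inhibition), compound 1 gives 58.3%. In this assay compound 2 gives 39.7%, and in this assay compound 3 gives 92.8%, the highest of the three numbers, with its gaps to compound 1 and to compound 2 both beyond the scatter.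

Compound 1 and compound 2 differ in one place, (cyano in place of chloro on an aromatic carbon), and this change produced a number 18.6 percentage points lower from compound 1 to compound 2 (beyond the scatter). Compound 1 and compound 3 share the same atoms joined differently; the difference between the two cores is not broken down here.

Compound 4 `N#Cc1ccc2c(-c3ccc(Cl)cc3)c(S(=O)(=O)c3ccc(F)cc3)cnc2c1` is not yet measured. It relates to compound 3 as compound 2 relates to compound 1: cyano in place of chloro on an aromatic carbon, with the surroundings of the place described in the same words in both cases, so this is the same change seen a second time. For the measured compounds named here, only the single pair compound 1 to compound 2 informs the size of the step, and the starting number for compound 3 stands much higher, so the transfer is uncertain. The step expected from compound 3 to compound 4 in this assay is a number 18.8 percentage points lower from compound 3 to compound 4 (beyond the scatter), modelled on a number 18.6 percentage points lower from compound 1 to compound 2 (beyond the scatter). For compound 4 the estimate in this assay is 74%, with a plausible range from 58% to 88%.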

Compound 4, a percentage reported as inhibition, at one concentration (the size of the read-out at that concentration, not a potency): 8.7%
For compound 4 the middle estimate is 65.3 percentage points above the measured one, and the stated range ends above it.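

The change of chloro to cyano on an aromatic carbon lowers the number on both cores in this assay, and on the core of compound 3 it gives a number 84.1 percentage points lower from compound 3 to compound 4 (beyond the scatter). The direction of the step is shared but its size is not, so a step read on one core cannot be carried to the other as a fixed amount: the same change on two cores in this assay, a number 18.6 percentage points lower (beyond the scatter) from compound 1 to compound 2 and a number 84.1 percentage points lower (beyond the scatter) from compound 3 to compound 4, 65.5 percentage points apart, beyond the scatter of two such steps. With one pair on each core and a read-out taken at one concentration, which gives the size of the inhibition and not a potency, these numbers do not show why the steps differ, how the change would behave on any further core, or how far potency itself moves.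

The compounds shown hold only chloro or cyano at this place, so it remains open how a methoxy group, an amine or a carboxylic acid there would read in this assay on either core. The groups held constant here, the 4-chlorophenyl and the fluorophenyl on the sulfonyl, are also untested as sources of variation, and replacing either with, for example, a plain phenyl or a longer alkyl chain could show whether the gap between the two steps persists.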